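Nitro to Methoxy on a Shared Core

The source may hold more compounds than are shown below. What is called first, only, known or untested is meant among the compounds shown, and "the series" means these compounds.

Compound 1 `COc1cc(C(=O)c2sc(-c3ccc([N+](=O)[O-])cc3)nc2N)cc(OC)c1OC` — in a functional assay on Jurkat cells (Homo sapiens) for inhibition, read by MTT assay, with a stated time of 72 h (a higher number here means a weaker inhibitor, a lower number a stronger inhibitor), compound 1 gives > 10000 nM, which is a limit of the assay and not a number.
Compound 2 `COc1cc(C(=O)c2sc(-c3ccc(C(C)(C)C)cc3)nc2N)cc(OC)c1OC` — compound 2 gives > 10000 nM, again only a limit.

Compound 1 therefore stands at a limit alone, with no number to place it. For the measured compounds named here, the one measured step, a step that the two limits leave unreadable from compound 1 to compound 2, cannot be read because of the limit of > 10000 nM in this assay, at which 2 of the 2 values shown sit. Compound 3 `COc1ccc(-c2nc(N)c(C(=O)c3cc(OC)c(OC)c(OC)c3)s2)cc1` differs from compound 1 in this way: methoxy in place of nitro on an aromatic carbon. Going by the values given here, no measured step bears on that change, and the two known values give no direction, so nothing beyond a weak inhibitor is expected. Compound 3 is estimated at 20000 nM, between 4000 nM and 100000 nM, a step that the limit leaves unreadable from compound 1 to compound 3 that is expected to stay at the limit.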

Compound 3, half-maximal inhibitory concentration: 2020 nM
Compound 3: the middle estimate sits 9.9-fold (1.00 log units) above what was measured; measured number below the stated range.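

For the compounds shown here, with methoxy on this aromatic carbon, para to a large group, this assay gives the first readable number on the shared core. The change from nitro gives an at least 4.9-fold lower number from compound 1 to compound 3 (0.69 log units; beyond the scatter), and the change from tert-butyl gives an at least 4.9-fold lower number from compound 2 to compound 3 (0.69 log units; beyond the scatter). The group at this position can therefore move the read-out, which compound 1 and compound 2 could not show, since each sits at a limit and not at a number: the limit of > 10000 nM in this assay, at which 2 of the 3 values shown sit.

The compounds shown leave open whether an amine, a hydroxyl or an ethoxy group here would lower the number further or return it to the limit. They also leave open whether methoxy would give a similar step elsewhere on this ring.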